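Swapping the Bicyclic Amide Head on a Sulfonamide Scaffold

The compounds below may be only part of what the source reports. "The series", "measured", "known", "first", "only" and "open" are said of these compounds alone.

Measured compounds:
Compound 1, `O=C(NCc1ccc(S(=O)(=O)c2ccccc2)cc1)c1cc2ccncc2s1`, in an assay for inhibition of Nicotinamide phosphoribosyltransferase (Homo sapiens), read by mass spectrometry, with stated times of 15 min and 30 min (a higher number here means a weaker inhibitor, a lower number a stronger inhibitor), compound 1 gives 7 nM.
Compound 2, `O=C(NCc1ccc(S(=O)(=O)N2CCCCC2)cc1)c1cc2cnccc2o1`, in this assay compound 2 gives 140 nM.

Of these two, compound 2 has the higher number in this assay, and its gap to compound 1 is beyond the usual scatter, so compound 2 is the weaker inhibitor of the pair. The two differ in more than one place, so their gap cannot be tied to a single change.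

Compound 3, `O=C(NCc1ccc(S(=O)(=O)N2CCCCC2)cc1)c1cnc2nccn2c1`, keeps the sulfonamide side of compound 2 and differs only at the amide head: a group of 9 heavy atoms (6 carbon, 3 nitrogen; one five-membered aromatic ring with 2 hetero atoms, one six-membered aromatic ring with 2 hetero atoms) in place of a group of 9 heavy atoms (7 carbon, 1 nitrogen, 1 oxygen; one five-membered aromatic ring with 1 hetero atom, one six-membered aromatic ring with 1 hetero atom), on a carbonyl carbon. Going by the values given here, no measured pair shows the effect of such a swap here, so the direction of the step is open. The step from compound 2 to compound 3 in this assay is estimated to be small, a 1.8-fold higher number from compound 2 to compound 3 (0.25 log units; within the scatter), with a wide range either way. Compound 3 is therefore expected to give 250 nM in this assay, between 50 nM and 1500 nM.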

Compound 3, half-maximal inhibitory concentration: 3 nM
For compound 3 the middle estimate is 83-fold (1.92 log units) above the measured one, outside the stated range (below it).
By their numbers in this assay, from the lowest: compound 3; then compound 1; then compound 2.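

Compound 2 and compound 3 differ only in the group on the carbonyl carbon, so this pair ties a change in this assay to the amide head alone, which the gap between compound 1 and compound 2 could not do. The swap gives a 47-fold lower number from compound 2 to compound 3 (1.67 log units; beyond the scatter) and marks this position as highly sensitive, even though the group that leaves and the group that enters both hold 9 heavy atoms. Nothing measured here bears on the cause of this step.

The compounds shown leave open whether the head of compound 3 would bring a similar gain on the other side of the molecule found in compound 1. They also leave open how much a methyl group or a chlorine atom added to this head would change the number.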